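Series notes: 4-methylphenylamino replaces cyclohexylamino on the shared core

The source may hold more compounds than are shown below. What is called first, only, known or untested is meant among the compounds shown, and "the series" means these compounds.

In a functional assay on HepG2 cells (Homo sapiens) for antiproliferative activity, read by CCK-8 assay, with a stated time of 72 h, tested at 2 uM (a higher number here means a stronger effect of the compound at the concentration tested, a lower number a weaker effect), compound 1 `Nc1ccccc1NC(=O)/C=C/c1ccc(Cn2cnc3c(NC4CCCCC4)nc(Cl)nc32)cc1` gives 3.83%, the lowest of the three numbers measured. Compound 3 `Nc1ccccc1NC(=O)c1ccc(Cn2cnc3c(Nc4ccc(-c5ccccn5)cc4)nc(Cl)nc32)cc1` gives 11.5%, which lies within the scatter of compound 1. Compound 2 `CCCCn1cnc2c(Nc3ccccc3)nc(NCOCc3ccc(/C=C/C(=O)Nc4ccccc4N)cc3)nc21` gives 27.9%, beyond the scatter above compound 1. Compound 4 `Cc1ccc(Nc2nc(Cl)nc3c2ncn3Cc2ccc(/C=C/C(=O)Nc3ccccc3N)cc2)cc1` is not yet measured in this assay. It differs from compound 1 by 4-methylphenyl in place of cyclohexyl on a nitrogen on an aromatic ring. Among the measured compounds shown here, no measured pair shows this same change, so its size is unknown from the data; compound 3 and compound 2 carry aromatic rings on the corresponding amine and sit at or above compound 1. A small step upward from compound 1 to compound 4 is therefore expected, estimated as a number 6.2 percentage points higher from compound 1 to compound 4 (within the scatter), probably within the scatter. Compound 4 is expected to give about 10%, with a range of 0% to 25%.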

Compound 4, a percentage reported as inhibition, at one concentration (the size of the read-out at that concentration, not a potency): 33.6%
For compound 4 the middle estimate is 23.6 percentage points below the measured one; measured number outside the range, above it.
By their numbers in this assay, from the lowest: compounds 1 and 3 (each within the scatter of the next); then compounds 2 and 4 (each within the scatter of the next).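

Among the compounds shown here, on the nitrogen on an aromatic ring of the shared core, 4-methylphenyl in place of cyclohexyl gives the first step that changes one place only: in this assay the read-out is a number 29.8 percentage points higher from compound 1 to compound 4 (beyond the scatter). This position therefore matters for the effect at the tested concentration, which compounds 2 and 3, differing in several places, could not show. No available measurement bears on the origin of this step.

Going by these compounds, whether the step follows from the aromatic ring itself or from its methyl stays open. A 4-methoxyphenyl or 4-chlorophenyl group on this nitrogen would give further readings at this position.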